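The compounds below may be only part of what the source reports. "The series", "measured", "known", "first", "only" and "open" are said of these compounds alone.

Compound 1, `CCc1cccc(NC(=O)c2cccc(/C=C3\CC(=O)N(c4ccccc4)C3=O)c2)c1`, compound 2, `Cc1ccc(N2C(=O)C/C(=C\c3cccc(C(=O)Nc4ccc(Cl)cc4)c3)C2=O)cc1`, and compound 3, `COc1ccc(NC(=O)c2cccc(/C=C3\CC(=O)N(c4ccc(C)cc4)C3=O)c2)cc1`, share one core and differ only in the aryl groups at the two ends. In an ADME assay on HCT-116 cells (Homo sapiens) for cytotoxicity, read by MTT assay, with a stated time of 72 h (on this read-out higher numbers stand for weaker inhibition and lower numbers for stronger inhibition), compound 1 gives 81200 nM. Compound 2 reaches only the limit of this assay, > 100000 nM. Compound 3 likewise reaches only the limit of this assay, > 100000 nM, so its place among these numbers is not fixed. Within the data shown here, the one single-point step recorded, a step that the two limits leave unreadable from compound 2 to compound 3, is therefore of unreadable size. Compound 4, `CCc1cccc(NC(=O)c2cccc(/C=C3\CC(=O)N(c4ccc(C)cc4)C3=O)c2)c1`, differs from compound 3 by 3-ethylphenyl in place of 4-methoxyphenyl on an amide-type nitrogen. Among the measured compounds shown here, no measured step directly bears on this exchange; compound 1 carries the same 3-ethylphenyl amide and sits near the limit at which two of the three values rest (the limit of > 100000 nM in this assay, at which 2 of the 3 values shown sit), so a weak result is expected for compound 4 in this assay, most likely a value reported only as a limit. The step of a number no higher from compound 3 to compound 4 (the limit leaves the size open) is thus expected to be unreadable or small. The estimate for compound 4 is 100000 nM, in the range 50000 nM to 300000 nM.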

Compound 4, half-maximal inhibitory concentration: 41500 nM
Compound 4: middle estimate off by 2.4-fold (0.38 log units), on the high side; measured number outside the range, below it.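

In this assay, 3-ethylphenyl on the amide-type nitrogen now gives a readable change, with an at least 2.4-fold lower number from compound 3 to compound 4 (0.38 log units; beyond the scatter) where it replaces 4-methoxyphenyl and an at least 2.4-fold lower number from compound 2 to compound 4 (0.38 log units; beyond the scatter) where it replaces 4-chlorophenyl. Both steps give only a minimum size, since each starts from a compound held at a limit: the limit of > 100000 nM in this assay, at which 2 of the 4 values shown sit. Methyl in place of hydrogen on an aromatic carbon gives a 2.0-fold lower number from compound 1 to compound 4 (0.29 log units; within the scatter), so among the four compounds shown, the two carrying 3-ethylphenyl, compound 1 and compound 4, are the ones that return numbers rather than limits, and the methyl change does not separate them.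

The compounds shown leave open whether this change rests on the ethyl group itself or on where it sits on the ring. They also leave open how a longer chain or an amine on that ring would read.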